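This account rests on a few compounds, and the source may have more. Where it says the series, first, only, none or still open, it means among the compounds named here.

Measured so far:
compound 1 `C=CC[C@H]1C[C@]2(CCc3ccc(OC)c(OC)c3)OCOC2=CC1=O` gives 3200 nM in a functional assay on NCI-H460 cells (Homo sapiens) for antiproliferative activity, with a stated time of 72 h; on this read-out higher numbers stand for weaker inhibition and lower numbers for stronger inhibition
compound 2 `C=CC[C@H]1C[C@]2([C@@H](C)Cc3ccc(OC)c(C)c3)OCOC2=CC1=O` gives 630 nM in this assay

On these two numbers compound 2 stands lowest. Its nearest neighbour, compound 1, gives a higher number, and the gap between them lies beyond the scatter. Compound 3 `C=CC[C@H]1C[C@]2([C@@H](C)Cc3ccc(OC)c(Cl)c3)OCOC2=CC1=O` follows from compound 2 by chloro in place of methyl on an aromatic carbon. Going by the values given here, no pair of measured compounds shows this change, so its size is unknown. The expected step is small, within the scatter, which is a 1.1-fold lower number from compound 2 to compound 3 (0.02 log units; within the scatter). Compound 3 is therefore estimated at 600 nM, with a range from 200 nM to 2000 nM.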

Compound 3, half-maximal inhibitory concentration: 640 nM
The estimate for compound 3 lay 1.1-fold (0.03 log units) below the measured number; the measured number falls inside the stated range.
By their numbers in this assay, from the lowest: compounds 2 and 3 (each within the scatter of the next); then compound 1.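

The step of a 1.0-fold higher number from compound 2 to compound 3 (0.01 log units; within the scatter) in this assay lies within the scatter, so at this aromatic carbon, ortho to a methoxy group, the read-out does not tell chloro from methyl. Going by these compounds alone, this is the first step between measured compounds that differ in one place, and it shows that this exchange leaves compound 3 within the scatter of compound 2. No supporting evidence offers an explanation for this result.

From the compounds shown here alone, whether this position accepts larger or different groups remains open. A plain hydrogen, a hydroxyl, a nitrile or an ethyl chain there could give quite another number.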